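Adding a Nitro Group to a Triazole Hydrazone

The compounds below may be only part of what the source reports. "The series", "measured", "known", "first", "only" and "open" are said of these compounds alone.

Compound 1 `Clc1cccc(CSc2nnc(-c3ccncc3)n2-c2ccccc2)c1`: 10500 nM in a functional assay on MCF7 cells (Homo sapiens) for inhibition, read by MTT assay, with a stated time of 48 h; a lower number here means a stronger inhibitor, a higher number a weaker inhibitor
Compound 2 `O=[N+]([O-])c1cccc(CSc2nnc(-c3ccncc3)n2-c2ccccc2)c1`: 18300 nM in this assay
Compound 3 `O=C(CSc1nnc(-c2ccncc2)n1-c1ccccc1)N/N=C/c1ccccc1`: 23600 nM in this assay

Compound 3 gives the highest of the three numbers, within the scatter of compound 2 but beyond it from compound 1. Compound 4 `O=C(CSc1nnc(-c2ccncc2)n1-c1ccccc1)N/N=C/c1ccc([N+](=O)[O-])cc1` differs from compound 3 by nitro in place of hydrogen on an aromatic carbon, para to a large group on the six-membered aromatic ring of carbon only. Among the measured compounds shown here, only one measured step bears on this change: a 1.7-fold higher number from compound 1 to compound 2 (0.24 log units; within the scatter), where a nitro group likewise entered an aromatic carbon, though there it replaced chloro rather than hydrogen. That step stayed within the scatter, so the expected step of a 1.2-fold higher number from compound 3 to compound 4 (0.07 log units; within the scatter) is small, if anything toward a slightly higher number. Compound 4 is therefore expected to give about 28000 nM in this assay, with a range from 12000 nM to 65000 nM.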

Compound 4, half-maximal inhibitory concentration: 15300 nM
Compound 4: the middle estimate sits 1.8-fold (0.26 log units) above what was measured, within the range that was stated.
By their numbers in this assay, from the lowest: compounds 1, 4, 2 and 3 (each within the scatter of the next, the first and the last beyond it).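

Changing phenyl to 4-nitrophenyl gives a 1.5-fold lower number from compound 3 to compound 4 (0.19 log units; within the scatter) in this assay so a nitro group on this aromatic carbon, para to a large group, does not move the number beyond the scatter. The earlier nitro step replaced chloro, whereas this one replaces hydrogen, and neither step leaves the scatter. No measured evidence bears on this result.

From the compounds shown here alone, whether an amine or a carboxylic acid at this same place would shift the number beyond the scatter remains open.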